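A Propyl Chain Gives Way to a Cyclobutyl Ring

The compounds below may be only part of what the source reports. "The series", "measured", "known", "first", "only" and "open" are said of these compounds alone.

Compound 3, `CCCNC1=NS(=O)(=O)c2cc(F)c(Cl)cc2N1`, gives 45300 nM in a functional assay (aorta) with Rattus norvegicus as the target, with a stated time of 90 min, at 37 degrees C; a lower number here means that less compound is needed, a higher number that more compound is needed for the effect. Of the two plain numbers shown, that is the highest; the nearest is compound 1, `CCCNC1=NS(=O)(=O)c2cc(Cl)c(Cl)cc2N1`, which gives 4700 nM in this assay, and the only measured step, a 9.6-fold higher number from compound 1 to compound 3 (0.98 log units; beyond the scatter), comes from a halogen swap on the aromatic ring. One value is a limit rather than a number, the limit of > 30000 nM in this assay, at which 1 of the 3 values shown sits: compound 2, `O=S1(=O)NC(NC2CC2)=Nc2cc(Cl)c(Cl)cc21`, gives > 30000 nM in this assay.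

Compound 4, `O=S1(=O)N=C(NC2CCC2)Nc2cc(Cl)c(F)cc21`, differs from compound 3 in one place: cyclobutyl in place of propyl on an amine nitrogen. Among the measured compounds shown here, no measured step touches this nitrogen substituent. The nearest guidance is the pair compound 1 and compound 2, where the propyl chain of compound 1 becomes a cyclopropyl ring in compound 2 and the number turns into a limit. A rise is therefore expected, and the step of a 2.2-fold higher number from compound 3 to compound 4 (0.34 log units; beyond the scatter) is estimated. Compound 4 is expected to give 100000 nM in this assay, with a range from 30000 nM to 400000 nM, and a good chance that only a limit is reported.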

Compound 4, half-maximal effective concentration: 39900 nM
For compound 4 the middle estimate is 2.5-fold (0.40 log units) above the measured one; measured number inside the range.
By their numbers in this assay, from the lowest: compound 1; then compounds 4 and 3 (each within the scatter of the next).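

In this assay, among the compounds shown here, cyclobutyl in place of propyl on the amine nitrogen gives a 1.1-fold lower number from compound 3 to compound 4 (0.06 log units; within the scatter) and is the first step at this position that can be read as a number. On the shared core of compound 3 and compound 4, the open propyl chain and the four-membered cyclobutyl ring therefore cannot be told apart at this nitrogen. Compound 2 still carries a limit and not a number, which leaves its cyclopropyl ring without a measured step: the limit of > 30000 nM in this assay, at which 1 of the 4 values shown sits.

From the compounds shown here alone, whether cyclobutyl behaves the same way on the core of compound 1 stays open. Also open, going by these compounds, is what this nitrogen would tolerate from a longer chain such as pentyl, from a phenyl ring, or from a chain ending in an amine.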